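Moving the ring nitrogen in a weakly active pair

The source may hold more compounds than are shown below. What is called first, only, known or untested is meant among the compounds shown, and "the series" means these compounds.

Measured compounds:
compound 1 `Cc1cc(C)c2cc(C#N)c(N3CCN(C(=O)c4ccccn4)CC3)nc2c1` gives 100000 nM in an assay on cells with Cystic fibrosis transmembrane conductance regulator variant F508del (Homo sapiens) as the target, read by fluorescence, with stated times of 24 h and 30 min; a higher number here means that more compound is needed for the effect, a lower number that less compound is needed
compound 2 `Cc1cc(C)c2cc(C#N)c(N3CCN(C(=O)c4ccncc4)CC3)nc2c1` gives 100000 nM

Compound 2 stands level with compound 1 in this assay; the step of no change at the digits printed from compound 1 to compound 2 (within the scatter) shows that moving the pyridine nitrogen made no difference. Compound 3 `Cc1cc(C)c2cc(C#N)c(N3CCN(C(=O)c4cccnc4)CC3)nc2c1` carries the change (pyridin-3-yl in place of pyridin-4-yl on a carbonyl carbon). Among the measured compounds shown here, the only measured step bearing on it is the one from compound 1 to compound 2, and it was flat. The expected step of no change at the digits printed from compound 2 to compound 3 (within the scatter) is therefore none beyond the scatter. Compound 3 is expected to give about 100000 nM, in the range 30000 nM to 100000 nM.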

Compound 3, half-maximal effective concentration: 100000 nM
Estimate against measurement, compound 3: no gap at the digits printed; measured number inside the range.
By their numbers in this assay, from the lowest: compounds 1, 2 and 3 (each within the scatter of the next).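

In this assay there is no change at the digits printed from compound 2 to compound 3 (within the scatter) and no change at the digits printed from compound 1 to compound 3 (within the scatter) so all three pyridine attachments on this carbonyl carbon have now been read, where the earlier pair covered only two. Among these compounds, the place of the ring nitrogen does not separate one from another. Nothing available accounts for this sameness.

Still open, going by these compounds, is whether something other than a pyridine ring on this carbonyl carbon, such as a plain phenyl ring, a carboxylic acid or a chain ending in an amine, would shift the value.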